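Chloromethyl for tert-butyl on the amide carbonyl

The source may hold more compounds than are shown below. What is called first, only, known or untested is meant among the compounds shown, and "the series" means these compounds.

compound 1 `CC(C)C(=O)Nc1cccc(S(=O)(=O)Oc2ccccc2C(C)C)c1`: 17000 nM
compound 2 `CC(C)c1ccccc1OS(=O)(=O)c1cccc(NC(=O)C(C)(C)C)c1`: 13000 nM

Two compounds share a core and were tested in a functional assay on M21 cells (Homo sapiens) for antiproliferative activity, read by sulforhodamine B assay, with a stated time of 48 h; a lower number here means a stronger inhibitor, a higher number a weaker inhibitor. They differ only at the carbonyl substituent, and the step of a 1.3-fold lower number from compound 1 to compound 2 (0.12 log units; within the scatter) is within the scatter. On these two numbers compound 2 stands with the lowest value, compound 1 being its nearest neighbour by that same small step.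

Compound 3 `CC(C)c1ccccc1OS(=O)(=O)c1cccc(NC(=O)CCl)c1` is not yet measured. It differs from compound 2 by chloromethyl in place of tert-butyl on a carbonyl carbon. Within the data shown here, the only measured step that touches this carbonyl substituent is the one from compound 1 to compound 2, and it was within the scatter. That change enlarged the saturated group, whereas the present one swaps it for a chlorine-bearing group, so the precedent gives little direction. A step of no change at the digits printed from compound 2 to compound 3 (within the scatter) is therefore expected, none beyond the scatter. For compound 3 the estimate is 13000 nM, with a range from 4500 nM to 38000 nM.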

Compound 3, half-maximal inhibitory concentration: 3900 nM
Beside the measured number, compound 3's estimate is 3.3-fold (0.52 log units) above it; the whole stated range lies above it.
By their numbers in this assay, from the lowest: compound 3; then compounds 2 and 1 (each within the scatter of the next).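

In this assay the carbonyl substituent now shows a real effect: chloromethyl gives a 3.3-fold lower number from compound 2 to compound 3 (0.52 log units; beyond the scatter) and, set against isopropyl, a 4.4-fold lower number from compound 1 to compound 3 (0.64 log units; beyond the scatter) on the same carbonyl carbon. Among these compounds, the earlier exchange between the two saturated groups stayed within the scatter, so this is the first sign that the number responds to what sits at this position, and it appears with a chlorine-bearing group of fewer heavy atoms. No measurement here bears on why the number falls.

The compounds shown leave open whether the lower number goes with the chlorine or with the smaller group, and a plain methyl or a bromomethyl group on this carbonyl carbon would separate the two. Also open, on these data alone, is whether a longer chain carrying chlorine, such as chloroethyl, would keep the step.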